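A tert-Butyl Extension on a Shared Inactive Core

This account rests on a few compounds, and the source may have more. Where it says the series, first, only, none or still open, it means among the compounds named here.

compound 1, `Cc1nc(Cc2ccccc2)n2c(O)nncc12` — in a functional assay for inhibition, with Homo sapiens as the target (a higher number here means a weaker inhibitor, a lower number a stronger inhibitor), compound 1 gives > 48000 nM, a limit
compound 2, `Cc1ncn2c(O)nncc12` — in this assay compound 2 gives > 48000 nM, a limit
compound 3, `Cc1nc(C)n2c(O)nncc12` — in this assay compound 3 gives > 48000 nM, a limit

Compound 3 stands at the limit of this assay and not at a number. The same holds for compound 1 and for compound 2, so that the limit of > 48000 nM in this assay, at which 3 of the 3 values shown sit, describes the whole measured set. The two steps that lead to compound 3, a step that the two limits leave unreadable from compound 1 to compound 3 and a step that the two limits leave unreadable from compound 2 to compound 3, cannot be read in size, as both of their ends are limits.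

Compound 4, `Cc1nc(CC(C)(C)C)n2c(O)nncc12`, differs from compound 3 by tert-butyl in place of hydrogen on a saturated chain carbon bound to an aromatic carbon. Within the data shown here, no measured step bears on this change in a readable way; both steps around compound 3 sit between limits. For compound 4 the step of a number no higher from compound 3 to compound 4 (the limit leaves the size open) is therefore expected to be small or not readable at all. Compound 4 is estimated at 48000 nM, in a range from 10000 nM to 200000 nM, with a high chance that this assay again reports only a limit.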

Compound 4, half-maximal inhibitory concentration: > 48000 nM
Compound 4: only a limit was reported; the forecaster's own chance of this, stated with the estimate: 85%; the middle value lies on the limit itself.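

In this assay compound 4 gives > 48000 nM, a limit. No step from compound 1, compound 2 or compound 3 to compound 4 can be read in size, and the set rests on one limit: the limit of > 48000 nM in this assay, at which 4 of the 4 values shown sit.

The compounds shown leave open what any change on the shared core does to the inhibition, since none gives a number.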